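Acetamide series: ethyl to methyl

The compounds below may be only part of what the source reports. "The series", "measured", "known", "first", "only" and "open" are said of these compounds alone.

Compound 1 `CCc1cccc(NC(=O)CN2CCN(c3ccccn3)CC2)c1` is the reference point of the set. In an assay on cells for agonist activity at D(4) dopamine receptor (Homo sapiens), read by luminescence and beta-arrestin recruitment, with a stated time of 90 min (on this read-out lower numbers stand for an effect already at smaller amounts and higher numbers for an effect only at larger amounts of compound), compound 1 gives 133 nM, the lowest of the two numbers recorded. Compound 2 `Cc1cccc(NC(=O)CN2CCN(c3cccc4ccccc34)CC2)c1` carries a different aromatic group on the shared core and gives 9210 nM in this assay; the gap between compound 2 and compound 1 lies beyond the scatter of the read-out. Compound 3 `Cc1cccc(NC(=O)CN2CCC(c3ccc(Cl)cc3)CC2)c1` is recorded as "not active" (no number reported) in this assay, with no number reported, and contributes no value for comparison. Among the compounds with values here, both compound 2 and compound 3 differ from compound 1 in more than one place, so no single-change step between measured compounds exists in this set.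

Compound 4 `Cc1cccc(NC(=O)CN2CCN(c3ccccn3)CC2)c1` is the next compound. It differs from compound 1 by hydrogen in place of methyl on a saturated chain carbon bound to an aromatic carbon; read one bond further out, ethyl becomes methyl and 3-ethylphenyl becomes 3-methylphenyl. Nothing measured here isolates that change, so the expectation rests on its counted size alone. The step in this assay is estimated as a 1.5-fold higher number from compound 1 to compound 4 (0.18 log units; within the scatter), in either direction and most likely within the scatter. Compound 4 is therefore expected to give about 200 nM in this assay, with a range from 60 nM to 700 nM.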

Compound 4, half-maximal effective concentration: 394 nM
The estimate for compound 4 lay 2.0-fold (0.29 log units) below the measured number; low and high end bracket the measured number.
By their numbers in this assay, from the lowest: compound 1; then compound 4; then compound 2.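

In this assay, within the data shown here, the change from ethyl to methyl on the 3-ethylphenyl group gives the first single-change step, a 3.0-fold higher number from compound 1 to compound 4 (0.47 log units; beyond the scatter). Although modest, this step lies beyond the scatter, so the methyl at the end of the ethyl chain has a measurable bearing on this read-out, with the lower number belonging to the ethyl compound. No supporting measurement accounts for the difference, and the step by itself gives no reason for it.

Among these compounds, with only this one pair, the step fixes a direction for ethyl and methyl alone and cannot yet be read as a trend with chain length. Going by these compounds, whether a propyl chain would continue in the same direction remains open, as does the outcome of a hydroxyl group or a fluorine on the saturated chain carbon bound to an aromatic carbon.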